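Swapping Chloro for Fluoro in a Weak Antiproliferative Series

A few compounds are considered here, and "the series" means these few. Any claim that something is new, unique, unknown or untested is made for them only; others in the source may bear on it.

Compound 1 `NC(=O)c1c(NC(=O)c2ccccc2Cl)sc2c1CCN(Cc1ccc(Cl)cc1Cl)C2` and compound 2 `NC(=O)c1c(NC(=O)c2ccccc2F)sc2c1CCN(Cc1ccc(Cl)cc1Cl)C2` share one core, while compound 3 `NC(=O)c1c(NC(=O)c2ccccc2Br)sc2c1CCN(C(=S)Nc1ccccc1Cl)C2` is built on another; the difference between the two cores is not broken down here. In a functional assay on HeLa cells (Homo sapiens) for antiproliferative activity, with a stated time of 24 h (a lower number here means a stronger inhibitor, a higher number a weaker inhibitor), compound 1 gives 21100 nM, compound 2 gives 27500 nM, and compound 3 gives 46900 nM. Compound 2 arises from compound 1 by fluoro in place of chloro on an aromatic carbon, a step that came out as a 1.3-fold higher number from compound 1 to compound 2 (0.12 log units; within the scatter). Compound 4 `NC(=O)c1c(NC(=O)c2ccccc2Br)sc2c1CCN(C(=S)Nc1ccccc1F)C2` has not yet been measured; it arises from compound 3 by the same change, (fluoro in place of chloro on an aromatic carbon), at a place described in identical words. Resting on the earlier step of a 1.3-fold higher number from compound 1 to compound 2 (0.12 log units; within the scatter), a step of similar small size is expected, a 1.3-fold higher number from compound 3 to compound 4 (0.11 log units; within the scatter). Compound 4 is therefore estimated at 60000 nM in this assay, within a range from 30000 nM to 120000 nM.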

Compound 4, half-maximal inhibitory concentration: > 50000 nM
Compound 4 ended at the assay's limit (the forecaster's own chance of this, stated with the estimate: 15%); the middle value is on the limit's open side.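

In this assay compound 4 sits at > 50000 nM, which is a limit of the assay and not a number. The change from chloro to fluoro can therefore be read here only as an at least 1.0-fold higher number from compound 3 to compound 4 (0.02 log units; that floor lies within the scatter), which shows no gain in strength on this core but leaves the true size of the step unknown. Set beside the earlier step, this neither shows that the change carries over from one core to the other nor shows that it behaves differently: the same change on two cores in this assay, a 1.3-fold higher number (0.12 log units; within the scatter) from compound 1 to compound 2 and an at least 1.0-fold higher number (0.02 log units; that floor lies within the scatter) from compound 3 to compound 4; the limit leaves it open whether they differ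

The compounds shown leave open how a methyl, a methoxy or an amine in place of the chloro would fare on either core. They also leave open whether any such group would bring these weak values down.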